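The compounds below may be only part of what the source reports. "The series", "measured", "known", "first", "only" and "open" are said of these compounds alone.

Compound 2 `O=C(/C=C/c1cccc(O)c1)c1cccc(-n2cc(-c3ccccc3)[nH]c2=O)c1` and compound 1 `COc1cc(/C=C/C(=O)c2cccc(-n3cc(-c4ccccc4)[nH]c3=O)c2)ccc1O` share the same core and differ only in the aryl group on the double-bonded chain. In a functional assay on SW-620 cells (Homo sapiens) for inhibition (on this read-out lower numbers stand for stronger inhibition of growth and higher numbers for weaker inhibition of growth), compound 1 gives 2290 nM, and compound 2 gives 2410 nM. Among the compounds with values here, the step of a 1.1-fold higher number from compound 1 to compound 2 (0.02 log units; within the scatter) leaves the two numbers within the scatter of each other, so compound 2 stands alongside compound 1, the only other measured compound, without being told apart from it.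

Compound 3 `O=C(/C=C/c1cccc(O)c1)c1cccc(-n2cc(-c3ccc(Cl)cc3)[nH]c2=O)c1` has not yet been measured. It differs from compound 2 by chloro in place of hydrogen on an aromatic carbon, the chlorine entering on the phenyl ring attached to the core, para to a large group. Within the data shown here, no measured step touches this ring: the only step known, from compound 1 to compound 2, concerns the aryl group on the chain and was within the scatter. There is thus no direct guide to what the chlorine will do. With one atom entering and nothing comparable on record, the step expected in this assay is a 1.2-fold lower number from compound 2 to compound 3 (0.08 log units; within the scatter), that is, none beyond the scatter in either direction. Compound 3 is therefore estimated at 2000 nM, with a range from 700 nM to 6000 nM.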

Compound 3, concentration for 50% growth inhibition: 1620 nM
For compound 3 the middle estimate is 1.2-fold (0.09 log units) above the measured one, and the stated range covers the measured number.
By their numbers in this assay, from the lowest: compounds 3, 1 and 2 (each within the scatter of the next).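

In this assay, within the data shown here, this is the first look at the phenyl ring on the shared core, since the earlier step touched only the aryl group on the chain: changing phenyl to 4-chlorophenyl gives a 1.5-fold lower number from compound 2 to compound 3 (0.17 log units; within the scatter). Compound 2 and compound 3 therefore cannot be told apart on this read-out, which shows that a chlorine can sit on this aromatic carbon, para to a large group, with growth inhibition staying on a level with that of the unsubstituted phenyl. No independent measurement is available to say what the chlorine does at this place.

As far as these compounds go, a single chloro cannot show whether this position responds to the kind of group placed there, so it remains open whether a methoxy group, an amine or a carboxylic acid in the same place would give a step beyond the scatter. From the compounds shown here alone, it is also open whether chloro would behave the same way at another carbon of this ring, or alongside the 4-hydroxy-3-methoxyphenyl group that compound 1 carries on its chain.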